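The compounds below may be only part of what the source reports. "The series", "measured", "known", "first", "only" and "open" are said of these compounds alone.

Compound 1 `O=C1NCCN1c1ccc(S(=O)(=O)Nc2ccc3[nH]ccc3c2)cc1`: 130 nM
Compound 2 `Cc1ccc(NS(=O)(=O)c2ccc(N3CCNC3=O)cc2)cc1`: 480 nM
Compound 3 `Cc1ccc(C)c(NS(=O)(=O)c2ccc(N3CCNC3=O)cc2)c1`: 46 nM

In a functional assay on HT-29 cells (Homo sapiens) for antiproliferative activity, read by sulforhodamine B assay, with a stated time of 48 h (on this read-out lower numbers stand for stronger inhibition and higher numbers for weaker inhibition), compound 2 gives the highest number of the three measured, while compound 1 and compound 3 both lie well beyond the scatter below it. Compound 4 `Cc1ccc(NS(=O)(=O)c2ccc(N3CCNC3=O)cc2)c(C)c1` differs from compound 2 in a single place: methyl in place of hydrogen on an aromatic carbon. For the measured compounds named here, one measured step bears on this change, the second methyl added to the same ring in a 10-fold lower number from compound 2 to compound 3 (1.02 log units; beyond the scatter), a large drop. The methyl in compound 4 is placed differently on that ring, so the same size of step is not assured, though a lower number is expected. For compound 4 the step is expected to be a 4.4-fold lower number from compound 2 to compound 4 (0.64 log units; beyond the scatter). Compound 4 is therefore expected to give about 110 nM, within a range from 35 nM to 350 nM.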

Compound 4, half-maximal inhibitory concentration: 180 nM
Compound 4: the middle estimate sits 1.6-fold (0.21 log units) below what was measured; the range from low to high includes it.
By their numbers in this assay, from the lowest: compound 3; then compounds 1 and 4 (each within the scatter of the next); then compound 2.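

In this assay a methyl ortho to a large group still lowers the number, with a 2.7-fold lower number from compound 2 to compound 4 (0.43 log units; beyond the scatter) as a modest step. The two dimethylphenyl groups are not interchangeable, with a 3.9-fold higher number from compound 3 to compound 4 (0.59 log units; beyond the scatter) on going from 2,5-dimethylphenyl to 2,4-dimethylphenyl, so the arrangement of the methyl groups matters and not only their number. Nothing available accounts for this gap. Still open, from the compounds shown here alone, is whether a group other than methyl on this carbon, such as an amine or a carboxylic acid, would keep the lower number.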